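A few compounds are considered here, and "the series" means these few. Any claim that something is new, unique, unknown or untested is made for them only; others in the source may bear on it.

Measured compounds:
- Compound 1 `O=C(c1cccc(F)c1)N1CC(c2nc(-c3cccc(Cl)c3)no2)C1`: in an assay on HEK293 cells for negative allosteric modulation of metabotropic glutamate receptor 5 (Homo sapiens), read by FLIPR (on this read-out lower numbers stand for stronger inhibition and higher numbers for weaker inhibition), compound 1 gives 780 nM.
- Compound 2 `CC1CCN(C(=O)N2CC(c3nc(-c4cccc(Cl)c4)no3)C2)CC1`: compound 2 reaches only the limit of > 10000 nM in this assay, a limit rather than a number; see (the limit of > 10000 nM in this assay, at which 1 of the 3 values shown sits).
- Compound 3 `O=C(c1ccccc1F)N1CC(c2nc(-c3cccc(Cl)c3)no2)C1`: in this assay compound 3 gives 670 nM.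

Compound 3 holds the lowest of the two numbers on hand, but its nearest neighbour is compound 1, with a 1.2-fold lower number from compound 1 to compound 3 (0.07 log units; within the scatter), so the two are not separated. Compound 4 `O=C(N1CCCCCC1)N1CC(c2nc(-c3cccc(Cl)c3)no2)C1` differs from compound 3 as follows: azepan-1-yl in place of 2-fluorophenyl on a carbonyl carbon.

Among the measured compounds shown here, the steps that bear on this change are those that exchange a fluorophenyl on the carbonyl carbon for a saturated nitrogen ring: an at least 12-fold higher number from compound 1 to compound 2 (1.10 log units; beyond the scatter) and, read back the other way, an at least 14-fold lower number from compound 2 to compound 3 (1.17 log units; beyond the scatter). Both are large and both end at, or start from, the limit. Azepan-1-yl is the same kind of group as 4-methylpiperidin-1-yl, so a step of comparable size and direction is expected, with a good chance that only a limit is reported.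

For compound 4 the expected step is a 22-fold higher number from compound 3 to compound 4 (1.35 log units; beyond the scatter). Compound 4 is therefore estimated at 15000 nM, between 4000 nM and 60000 nM.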

Compound 4, half-maximal inhibitory concentration: > 10000 nM
Compound 4 ended at the assay's limit; the forecaster's own chance of this, stated with the estimate: 70%; the middle value lies beyond the limit too.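

Exchanging the fluorophenyl on the carbonyl carbon for azepan-1-yl gives an at least 14-fold higher number from compound 3 to compound 4 (1.17 log units; beyond the scatter) and an at least 12-fold higher number from compound 1 to compound 4 (1.10 log units; beyond the scatter), so the 2-fluorophenyl and 3-fluorophenyl compounds both stand clear of this seven-membered ring. Until now a single saturated nitrogen ring, 4-methylpiperidin-1-yl, stood behind this loss; a second such ring now behaves alike, and the value of compound 4, like that of compound 2, is a limit and not a number: the limit of > 10000 nM in this assay, at which 2 of the 4 values shown sit. The step between compound 2 and compound 4 cannot be read, and the two rings cannot be ranked.

Going by these compounds, whether the loss goes with the saturated ring or with the ring nitrogen on the carbonyl carbon stays open, and cyclohexyl at this place would separate the two. Also open, on these data alone, is whether a pyridyl ring or a further substituent on the phenyl ring would give a lower number than compound 1 and compound 3 share within the scatter.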